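Swapping the phenyl substituent on a shared aromatic nitrogen

The source may report more compounds than this note shows. Statements on the series, on what has been measured and on what is new or still open speak of the compounds shown alone.

Compound 1 `C=CC(=O)Nc1cc(Nc2ncc3ncn(-c4ccc(Cl)cc4)c3n2)c(OC)cc1N(C)CCN(C)C` gives 7690 nM in an ADME assay on HT-29 cells (Homo sapiens) for cytotoxicity, read by MTT assay, with a stated time of 72 h; a higher number here means a weaker inhibitor, a lower number a stronger inhibitor.
Compound 2 `C=CC(=O)Nc1cc(Nc2ncc3ncn(-c4ccccc4F)c3n2)c(OC)cc1N(C)CCN(C)C` gives 9750 nM in this assay.

Among these two numbers compound 2 carries the higher one, but only just: a 1.3-fold higher number from compound 1 to compound 2 (0.10 log units; within the scatter), so the two compounds cannot be told apart on this evidence. Compound 3 `C=CC(=O)Nc1cc(Nc2ncc3ncn(-c4ccc(F)c(Cl)c4)c3n2)c(OC)cc1N(C)CCN(C)C` has not yet been measured in this assay. It differs from compound 2 in a single place: 3-chloro-4-fluorophenyl in place of 2-fluorophenyl on an aromatic nitrogen. For the measured compounds named here, the one measured step that bears on this change is the earlier swap of the group on the same aromatic nitrogen, which stayed within the scatter. With nothing pointing either way, no step beyond the scatter is expected here, in either direction. Compound 3 is therefore estimated at 8500 nM, with a range from 3000 nM to 25000 nM. The expected step is a 1.1-fold lower number from compound 2 to compound 3 (0.06 log units; within the scatter).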

Compound 3, half-maximal inhibitory concentration: 1610 nM
The estimate for compound 3 lay 5.3-fold (0.72 log units) above the measured number; measured number below the stated range.
By their numbers in this assay, from the lowest: compound 3; then compounds 1 and 2 (each within the scatter of the next).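

In this assay the entering 3-chloro-4-fluorophenyl gives a 6.1-fold lower number from compound 2 to compound 3 (0.78 log units; beyond the scatter) and a 4.8-fold lower number from compound 1 to compound 3 (0.68 log units; beyond the scatter) and so shows that the group on this aromatic nitrogen can shift the number beyond the scatter. The earlier swap between 4-chlorophenyl and 2-fluorophenyl stayed within the scatter and gave no sign of this. Both new steps are modest, and compound 3 stands apart from compounds 1 and 2 as the one whose phenyl ring carries two halogens rather than one.

The compounds shown leave open whether both halogens are needed or one of them in a different place would do. They also leave open how a phenyl ring carrying a methoxy group or an amine would read here, or a simple alkyl chain in place of the ring. No measurement available here explains the new steps.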